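A few compounds are considered here, and "the series" means these few. Any claim that something is new, unique, unknown or untested is made for them only; others in the source may bear on it.

In a functional assay on A549 cells (Homo sapiens) for inhibition (a higher number here means a weaker inhibitor, a lower number a stronger inhibitor), compound 2 `COc1cc(/C=C/c2ccc3c(ccn3S(=O)(=O)c3ccccc3)c2)cc(OC)c1OC` gives > 5000 nM as a limit and not a number. Compound 3 `COc1cc(/C=C\c2ccc3c(ccn3S(=O)(=O)c3ccccc3)c2)cc(OC)c1OC` also gives only a limit with > 5000 nM as its entry. Among the measured compounds shown here, the one measured step is a step that the two limits leave unreadable from compound 2 to compound 3 with the fact that compounds 2 and 3 differ only in the configuration as drawn as its whole content, so it gives no size for a change on the nitrogen. Compound 1 `COc1cc(/C=C\c2ccc(N(C)C)c(N)c2)cc(OC)c1OC` gives 4 nM in this assay but differs from compound 2 in more than one place. For the measured compounds named here, compound 4 `COc1cc(/C=C/c2ccc3c(ccn3C)c2)cc(OC)c1OC` differs from compound 2 by methyl in place of phenylsulfonyl on an aromatic nitrogen as its one change. No measured step sizes this change, so only a modest move toward stronger inhibition is expected, and another limit remains possible. The estimated step is an at least 2.0-fold lower number from compound 2 to compound 4 (0.30 log units; that floor lies within the scatter) in that direction. For compound 4 the estimated value is 2500 nM with 300 nM to 10000 nM as the expected range.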

Compound 4, half-maximal inhibitory concentration: 470 nM
Compound 4: the middle estimate sits 5.3-fold (0.73 log units) above what was measured; the range from low to high includes it.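

In this assay, among the compounds shown here, the change from phenylsulfonyl to methyl on an aromatic nitrogen gives an at least 10-fold lower number from compound 2 to compound 4 (1.02 log units; beyond the scatter) and is the first readable step at this position. For the compounds shown here, compound 4 is the first compound on this nitrogen series to carry a number and not a limit. Going by these compounds, compound 2 holds only a limit, so this step is a floor and its full size stays unknown: the limit of > 5000 nM in this assay, at which 2 of the 4 values shown sit.

Open, on these data alone, is how a free hydrogen, an ethyl group or a longer chain on that nitrogen would read. Also open, as far as these compounds go, is whether the Z double bond would read differently from the E double bond with methyl in place.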